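The source may report more compounds than this note shows. Statements on the series, on what has been measured and on what is new or still open speak of the compounds shown alone.

Compound 1 `Nc1ccc(Oc2ccccc2-c2ccc(S(=O)(=O)NCCNC(=O)Nc3ccc(Cl)cc3)s2)cc1`: > 20000 nM in an ADME assay on HEK-293T cells (Homo sapiens) for cytotoxicity, read by CCK-8 assay, with a stated time of 48 h (on this read-out higher numbers stand for weaker inhibition and lower numbers for stronger inhibition), a limit of the assay.
Compound 2 `O=C(NCCNS(=O)(=O)c1ccc(-c2ccccc2OCc2ccccc2)s1)Nc1cc(C(F)(F)F)cc(C(F)(F)F)c1`: > 20000 nM in this assay, a limit.
Compound 3 `O=C(NCCNS(=O)(=O)c1ccc(-c2ccccc2Oc2ccc([N+](=O)[O-])c([N+](=O)[O-])c2)s1)Nc1ccc(Cl)cc1`: > 20000 nM in this assay, a limit.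

The piece follows the change from compound 1 to the not yet measured compound 4 `Cc1cc(C)cc(NC(=O)NCCNS(=O)(=O)c2ccc(-c3ccccc3Oc3ccc(N)cc3)s2)c1`. Compound 1 stands only at a limit of this assay, like every other measured compound, as the limit of > 20000 nM in this assay, at which 3 of the 3 values shown sit, shows. Among the measured compounds shown here, the one measured step, a step that the two limits leave unreadable from compound 1 to compound 3, is unreadable, since both of its values are limits. The change to compound 4 is 3,5-dimethylphenyl in place of 4-chlorophenyl on an amide-type nitrogen. For the measured compounds named here, no measured step bears on this change, and all measured values sit at the limit, so no step beyond the scatter is expected. The step from compound 1 to compound 4 is estimated as a step that the limit leaves unreadable from compound 1 to compound 4. Compound 4 is therefore expected to give 30000 nM in this assay, with a range from 12000 nM to 100000 nM.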

Compound 4, half-maximal inhibitory concentration: > 20000 nM
Compound 4: no number, only a limit; the forecaster's own chance of this, stated with the estimate: 85%; the middle value is on the limit's open side.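

Compound 1 and compound 4 both stand only at a limit of this assay, so no step can be read for 3,5-dimethylphenyl in place of 4-chlorophenyl. The compounds shown leave open at what concentration any of them would reach half-maximal inhibition.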